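The compounds below may be only part of what the source reports. "The series", "measured", "known", "first", "only" and "open" are said of these compounds alone.

Measured so far in a functional assay on BXPC-3 cells (Homo sapiens) for inhibition, read by MTT assay, with a stated time of 7 days; a lower number here means a stronger inhibitor, a higher number a weaker inhibitor:
- compound 1 `CCN(CC)S(=O)(=O)c1ccc(S(=O)(=O)N2CCC[C@@H](C(=O)NC3COC3)C2)cc1`: 13800 nM
- compound 2 `O=C([C@@H]1CCCN(S(=O)(=O)c2ccc(S(=O)(=O)C3CC3)cc2)C1)N1CCC(F)(F)CC1`: 129 nM
- compound 3 `CN(C)S(=O)(=O)c1ccc(S(=O)(=O)N2CCC[C@@H](C(=O)N3CCC(F)(F)CC3)C2)cc1`: 560 nM

Compound 1 gives the highest of the three numbers in this assay and is the weakest inhibitor of the set; compound 3 lies nearest to it and compound 2 furthest, both gaps being beyond the scatter. Going by the values given here, the only step between measured compounds is a 4.3-fold higher number from compound 2 to compound 3 (0.64 log units; beyond the scatter), a modest shift that concerns the sulfonyl substituent and does not touch the amide side of the core.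

Compound 4 `CCN(CC)S(=O)(=O)c1ccc(S(=O)(=O)N2CCC[C@@H](C(=O)N3CCS(=O)(=O)CC3)C2)cc1` is the unmeasured compound. It differs from compound 1 by 1,1-dioxothiomorpholin-4-yl in place of (oxetan-3-yl)amino on a carbonyl carbon. Among the compounds with values here, no measured pair isolates a change at this carbonyl carbon: compounds 2 and 3 differ from compound 1 at both the sulfonyl substituent and the amide side, so their much lower numbers cannot be assigned to either end alone. The expectation therefore rests on weak ground. Given that compounds 2 and 3 both reach far lower values than compound 1 with a different amide, a move away from the (oxetan-3-yl)amino amide is expected to lower the number, and the step of a 4.6-fold lower number from compound 1 to compound 4 (0.66 log units; beyond the scatter) is estimated with wide uncertainty. Compound 4 is expected to give about 3000 nM in this assay, in the range 800 nM to 11000 nM.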

Compound 4, half-maximal inhibitory concentration: 4430 nM
For compound 4 the middle estimate is 1.5-fold (0.17 log units) below the measured one; the range from low to high includes it.
By their numbers in this assay, from the lowest: compound 2; then compound 3; then compound 4; then compound 1.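

Going by these compounds alone, compounds 1 and 4 form the first pair that changes only the amide side, so this position can now be read with the rest of the molecule held fixed: in this assay, 1,1-dioxothiomorpholin-4-yl in place of (oxetan-3-yl)amino on a carbonyl carbon gives a 3.1-fold lower number from compound 1 to compound 4 (0.49 log units; beyond the scatter). The position therefore affects the number on its own, although this step is modest. The amide hydrogen of compound 1 is absent from compound 4 and the number still falls, so that hydrogen is not required for the lower number in this pair, and nothing shown bears on why the number moves.

Still open is how much of the distance between compound 1 and compounds 2 and 3 belongs to the amide side and how much to the sulfonyl substituent, as no pair shown separates the two for those compounds. Also open, going by these compounds, is whether the step follows the larger ring or the ring sulfone itself: morpholin-4-yl or piperidin-1-yl on the same carbonyl carbon would divide these two features.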